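Trifluoromethoxy in place of methyl: an expected step

The compounds below may be only part of what the source reports. "The series", "measured", "known", "first", "only" and "open" are said of these compounds alone.

In an ADME assay for permeability, using PAMPA, at pH 7.4 (a higher number here means that the compound crosses the layer faster, a lower number that the compound crosses the layer more slowly), compound 2 `Cc1ccc(NC(=O)Nc2cc(C)nc3ccccc23)cc1` gives 669 10^-6 cm/s and sits within the scatter of compound 3 `Cc1cc(NC(=O)Nc2ccc(F)c(F)c2)c2ccccc2n1` with its 478 10^-6 cm/s on the same scale. Compound 1 `Cc1cc(NC(=O)Nc2ccc(C)c(Cl)c2)c2ccccc2n1` gives 262 10^-6 cm/s and lies beyond the scatter below compound 2. Compound 4 `Cc1cc(NC(=O)Nc2ccc(OC(F)(F)F)cc2)c2ccccc2n1` carries trifluoromethoxy in place of methyl on an aromatic carbon. Going by the values given here, the only measured step in one place is a 2.6-fold higher number from compound 1 to compound 2 (0.41 log units; beyond the scatter) with hydrogen in place of chloro on an aromatic carbon. It is modest, and it is a different change, so it guides only loosely. Read backwards, it suggests a lower number here. The expected step is a 1.9-fold lower number from compound 2 to compound 4 (0.28 log units; within the scatter) in this assay and its size is expected to lie close to the scatter. Compound 4 is estimated at 350 10^-6 cm/s with 150 10^-6 cm/s and 750 10^-6 cm/s as the expected ends of its range.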

Compound 4, apparent permeability: 531 10^-6 cm/s
Estimate against measurement, compound 4: 1.5-fold (0.18 log units) below; the range from low to high includes it.
By their numbers in this assay, from the lowest: compounds 1, 3, 4 and 2 (each within the scatter of the next, the first and the last beyond it).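

In this assay, trifluoromethoxy in place of methyl on an aromatic carbon, para to a large group, gives a 1.3-fold lower number from compound 2 to compound 4 (0.10 log units; within the scatter). This place on the ring therefore takes a group with more heavy atoms and a hydrogen-bond acceptor without a shift beyond the scatter, which the earlier step, a different change, could not show. Nothing measured here gives a reason for this result.
Going by these compounds, whether an amine or a carboxylic acid at this place would also stay within the scatter of compound 2 remains open, and so does the effect of a longer alkoxy chain.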